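The source may report more compounds than this note shows. Statements on the series, on what has been measured and on what is new or still open speak of the compounds shown alone.

Three compounds bearing the same nucleotide core have been examined in an assay on isolated protein for inhibition of hexokinase-2 (Rattus norvegicus), with a stated time of 6 h, tested at 10 mM; on this read-out higher numbers stand for more inhibition at the one concentration tested (going by the name of the read-out) and lower numbers for less inhibition. Compound 1 `CN(CCCCN(C)C(=O)CCCNc1ncnc2c1ncn2[C@@H]1O[C@H](COP(=O)(O)OP(=O)(O)OP(=O)(O)O)[C@@H](O)[C@H]1O)C(=O)CCCNC(=O)CI` gives 0%, compound 3 `Nc1ncnc2c1nc(NCCCCCCNC(=O)CI)n2[C@@H]1O[C@H](COP(=O)(O)OP(=O)(O)OP(=O)(O)O)[C@@H](O)[C@H]1O` gives 0%, and compound 2 `O=C(CI)NCCCCCCCNc1ncnc2c1ncn2[C@@H]1O[C@H](COP(=O)(O)OP(=O)(O)OP(=O)(O)O)[C@@H](O)[C@H]1O` gives 30%, the highest of the three, standing beyond the scatter above both compound 1 and compound 3. Compound 4 `O=C(CI)NCCC(=O)NCCCCCCNc1ncnc2c1ncn2[C@@H]1O[C@H](COP(=O)(O)OP(=O)(O)OP(=O)(O)O)[C@@H](O)[C@H]1O` has not yet been measured in this assay. It differs from compound 2 in one place: a group of 10 heavy atoms (5 carbon, 2 nitrogen, 2 oxygen, 1 iodine; no ring) in place of a group of 6 heavy atoms (3 carbon, 1 nitrogen, 1 oxygen, 1 iodine; no ring), on a saturated chain carbon, six bonds along the chain from a nitrogen on an aromatic ring. Within the data shown here, no measured pair shows a change of this kind, so the size of the step is uncertain; the account expects a modest decrease from compound 2 to compound 4 in this assay, of about the size of the scatter, a number 10 percentage points lower from compound 2 to compound 4 (within the scatter). Compound 4 is therefore expected to give about 20%, within a range from 0% to 40%.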

Compound 4, a percentage reported as inhibition, at one concentration (the size of the read-out at that concentration, not a potency): 0%
Beside the measured number, compound 4's estimate is 20 percentage points above it; the range from low to high includes it.
By their numbers in this assay, from the lowest: compounds 1, 3 and 4 (each within the scatter of the next); then compound 2.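

In this assay, among these compounds, this is the only step that can be read, and it is large: the change gives a number 30 percentage points lower from compound 2 to compound 4 (beyond the scatter). On this saturated chain carbon, then, the group of 10 heavy atoms does not retain the inhibition seen with the (((iodomethyl)carbonyl)amino)methyl group. Nothing available explains this loss. On these data alone, it remains open whether an unbroken longer carbon chain ending in the same iodomethyl carbonyl amino group would retain inhibition. The same question applies to a chloromethyl carbonyl amino end on the chain of compound 2.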